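A Fluoro Swap on Compound 2

The source may report more compounds than this note shows. Statements on the series, on what has been measured and on what is new or still open speak of the compounds shown alone.

Going by the values given here, compound 2 `O=C(/C=C1\CCc2ccccc21)NC1CC1` gives 150 mg/kg in a functional assay on the whole organism with Mus musculus as the target (a higher number here means that more compound is needed for the effect, a lower number that less compound is needed), which places it at the upper end of the three numbers known so far. Compound 3 `O=C(/C=C1\CCc2cc(F)ccc21)NC1CC1` gives 81 mg/kg, within the scatter of compound 2. Compound 1 `Cc1cccc2c1CC/C2=C\C(=O)NC1CC1` gives 40 mg/kg, clearly a lower number.

Compound 4 `O=C(/C=C1\CCc2ccc(F)cc21)NC1CC1` has fluoro in place of hydrogen on an aromatic carbon of compound 2 (fluoro in place of hydrogen on an aromatic carbon). The closest guide is the same kind of swap at a different aromatic carbon, which gave a 1.9-fold lower number from compound 2 to compound 3 (0.27 log units; within the scatter). The other guide involves a different group, so it bears less directly: a 3.8-fold higher number from compound 1 to compound 2 (0.57 log units; beyond the scatter). In both steps, the compound with a group on the aromatic carbon has the lower number, but two steps are thin evidence, and no fluoro at this carbon has been measured. A small move towards a lower number is therefore expected, with the estimate being a 1.5-fold lower number from compound 2 to compound 4 (0.18 log units; within the scatter). For compound 4 the estimated value is 100 mg/kg, with an expected range of 45 mg/kg to 200 mg/kg.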

Compound 4, dose for half-maximal effect: 66 mg/kg
Beside the measured number, compound 4's estimate is 1.5-fold (0.18 log units) above it; the range from low to high includes it.
By their numbers in this assay, from the lowest: compounds 1, 4, 3 and 2 (each within the scatter of the next, the first and the last beyond it).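

In this assay, fluoro on this aromatic carbon gives a 2.3-fold lower number from compound 2 to compound 4 (0.36 log units; beyond the scatter), a modest step but one that lies beyond the usual scatter, whereas the same swap at the other aromatic carbon gives a 1.9-fold lower number from compound 2 to compound 3 (0.27 log units; within the scatter), which stays within it. Even so, compound 3 and compound 4 lie within the scatter of each other, so these numbers do not firmly separate the two carbons. Nothing available explains why the number changes at this position.

Going by these compounds, it remains open whether chlorine, bromine or a methoxy group on this same carbon would move the number further than fluoro does. Also open, on these data alone, is whether this fluoro and the methyl group of compound 1 would add up if both sat on the shared core.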